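The source may hold more compounds than are shown below. What is called first, only, known or untested is meant among the compounds shown, and "the series" means these compounds.

Measured so far in an ADME assay on WI-38 cells (Homo sapiens) for cytotoxicity, read by sulforhodamine B assay, with a stated time of 24 h; on this read-out lower numbers stand for stronger inhibition and higher numbers for weaker inhibition

- Compound 1 `N#CCC(=O)N/N=C1\C(=O)Nc2ccc(S(=O)(=O)N3CCOCC3)cc21` gives 302000 nM
- Compound 2 `Cc1ccc(/N=C2\C(=O)Nc3ccc(S(=O)(=O)N4CCOCC4)cc32)cc1` gives 309000 nM
- Compound 3 `N/N=C1\C(=O)Nc2ccc(S(=O)(=O)N3CCOCC3)cc21` gives 391000 nM

Compound 3 stands at 391000 nM and lies within the scatter of both others, so the three cannot be ranked. The next compound to test is compound 4 `O=C1Nc2ccc(S(=O)(=O)N3CCOCC3)cc2/C1=N/NC(=O)c1ccccc1`, which has benzoyl in place of hydrogen on an amine nitrogen. Among the measured compounds shown here, no measured compound carries benzoyl, so the evidence is indirect. Compound 1 carries (cyanomethyl)carbonyl on this same nitrogen, and swapping that group for hydrogen changes little (a 1.3-fold higher number from compound 1 to compound 3 (0.11 log units; within the scatter)). Compound 2 has 4-methylphenyl on the double-bonded nitrogen, and amino in its place also changes little (a 1.3-fold higher number from compound 2 to compound 3 (0.10 log units; within the scatter)). Neither step goes beyond the scatter, so no real shift in either direction is expected in this assay. The expected step is small (a 1.2-fold lower number from compound 3 to compound 4 (0.09 log units; within the scatter)). For compound 4 the estimated value is 320000 nM, with an expected range from 150000 nM to 600000 nM.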

Compound 4, half-maximal inhibitory concentration: 295000 nM
Estimate against measurement, compound 4: 1.1-fold (0.04 log units) above; low and high end bracket the measured number.
By their numbers in this assay, from the lowest: compounds 4, 1, 2 and 3 (each within the scatter of the next).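

In this assay, benzoyl on the amine nitrogen adds a six-membered aromatic ring, yet the result stays within the scatter (a 1.3-fold lower number from compound 3 to compound 4 (0.12 log units; within the scatter)). The same holds for the swap of cyanomethyl for phenyl on the carbonyl carbon (a 1.0-fold lower number from compound 1 to compound 4 (0.01 log units; within the scatter)) and for benzamido in place of 4-methylphenyl on the double-bonded nitrogen (a 1.0-fold lower number from compound 2 to compound 4 (0.02 log units; within the scatter)), so even this larger aromatic group does not separate compound 4 from the other three. Nothing measured here gives a reason for this lack of separation.

Going by these compounds, it remains open whether a different kind of group on this amine nitrogen, such as a longer chain ending in an amine or a carboxylic acid, would move the number beyond the scatter. On these data alone, it is also open whether changes elsewhere on the shared core would do so.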